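Cyclopropylsulfonyl for Cyclopropylcarbonyl on a Bridged Amine

The source may report more compounds than this note shows. Statements on the series, on what has been measured and on what is new or still open speak of the compounds shown alone.

Measured compounds:
compound 1, `C[C@@H]1C[C@H]1C(=O)N1CCN(c2cnc(C#N)c(-c3cnn(C)c3)n2)C[C@H]1C`: 1.6
compound 2, `C[C@@H]1CN(c2ncc(C#N)c(-c3cnn(C)c3)n2)CCN1C(=O)C1CC1`: 2
compound 3, `Cn1cc(-c2ncc(C#N)c(N3C[C@@H]4C[C@H]3CN4C(=O)C3CC3)n2)cn1`: 1.1

Of the compounds shown here, three sharing one core have been read in a physicochemical assay for lipophilicity, read by HPLC; a lower number here means a more polar compound, a higher number a more lipophilic compound. In this assay compound 1 gives 1.6 and compound 2 gives 2. Compound 3, with its bridged ring system, gives 1.1, the lowest of the three values; its gap to compound 1 is the nearest of the two, and its gap to compound 2 the furthest, and both gaps lie beyond the usual scatter. Within the data shown here, none of these three differs from another in a single place, so no step between measured compounds can be read off.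

The next compound, compound 4, `Cn1cc(-c2ncc(C#N)c(N3C[C@@H]4C[C@H]3CN4S(=O)(=O)C3CC3)n2)cn1`, keeps the whole of compound 3 apart from one group. The change is: cyclopropylsulfonyl in place of cyclopropylcarbonyl on an amine nitrogen in a ring

Among the measured compounds shown here, no step of this kind exists among the measured compounds, so the expectation rests on the size of the change alone: cyclopropylsulfonyl in place of cyclopropylcarbonyl, one heavy atom more and one additional hydrogen-bond acceptor. The step from compound 3 to compound 4 is expected to be small, no change at the digits printed from compound 3 to compound 4 (within the scatter), and not beyond the scatter in either direction. For compound 4 the estimated value in this assay is therefore 1.1, with a range from 0.6 to 1.6.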

Compound 4, distribution coefficient: 1.6
Beside the measured number, compound 4's estimate is 0.50 log units below it; the measured number falls inside the stated range.
By their numbers in this assay, from the lowest: compound 3; then compounds 1 and 4 (each within the scatter of the next); then compound 2.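

In this assay, cyclopropylsulfonyl in place of cyclopropylcarbonyl on this amine nitrogen in a ring gives a number 0.50 log units higher from compound 3 to compound 4 (beyond the scatter), the only step shown so far that can be read at a single place. It shows that the number at this position responds to the exchange of the carbonyl for the sulfonyl even though the cyclopropyl ring stays and the rest of the compound is untouched, and that the number moves upward although the entering group has 2 hydrogen-bond acceptors against 1 in the group that leaves. No measurement shown here accounts for the direction or the size of this step.

From the compounds shown here alone, this is a single pair in a single assay, so it remains open whether the same exchange on the amide nitrogen of compound 1 or compound 2 would give a step of like size and direction. Also open, going by these compounds, is how this assay would read with other groups on this nitrogen, such as methylsulfonyl, dimethylaminosulfonyl or a dimethylaminocarbonyl urea.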